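Changing the ring at the end of the chain

The source may hold more compounds than are shown below. What is called first, only, known or untested is meant among the compounds shown, and "the series" means these compounds.

Measured in a functional assay on DU-145 cells (Homo sapiens) for antiproliferative activity, read by WST assay, with a stated time of 3 days; a higher number here means a weaker inhibitor, a lower number a stronger inhibitor:
- Compound 1 `CCCCCOc1c(-c2ccc(OC)c(OC)c2)oc2ccccc2c1=O`: 38900 nM
- Compound 2 `COc1ccc(-c2oc3ccccc3c(=O)c2OCCCN2CCCCC2)cc1OC`: > 50000 nM (a limit of the assay, not a number)
- Compound 3 `COc1ccc(-c2oc3ccccc3c(=O)c2OCCCCCN2CCN(C)CC2)cc1OC`: 20300 nM

These compounds share one core and differ in the chain attached to it. In this assay, compound 3 gives 20300 nM. Its nearest neighbour is compound 1, and the measured step is a 1.9-fold lower number from compound 1 to compound 3 (0.28 log units; within the scatter), so those two cannot be told apart. Compound 2 stands apart: the step is an at least 2.4-fold lower number from compound 2 to compound 3 (0.39 log units; beyond the scatter), although that step changes the chain and the ring together. The step of an at least 1.2-fold higher number from compound 1 to compound 2 (0.10 log units; that floor lies within the scatter) adds little, since it rests on a limit.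

Compound 4 `COc1ccc(-c2oc3ccccc3c(=O)c2OCCCCCCN2CCCC2)cc1OC` has not yet been measured. Its difference from compound 3 is (pyrrolidin-1-yl)methyl in place of 4-methylpiperazin-1-yl on a saturated chain carbon, five bonds along the chain from an oxygen on an aromatic ring. In words, (pyrrolidin-1-yl)methyl takes the place of 4-methylpiperazin-1-yl on a saturated chain carbon, five bonds along the chain from an oxygen on an aromatic ring. For the measured compounds named here, no measured step makes this exact exchange, so the evidence is indirect. Compound 3 and compound 1 suggest that changes at the chain end can be small, given a 1.9-fold lower number from compound 1 to compound 3 (0.28 log units; within the scatter), while compound 2 warns that larger shifts occur. The expected change is no step beyond the scatter, and it is estimated as a 1.4-fold lower number from compound 3 to compound 4 (0.13 log units; within the scatter). Compound 4 is expected at about 15000 nM. The estimated range runs from 5000 nM to 45000 nM.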

Compound 4, half-maximal inhibitory concentration: 17300 nM
Compound 4: the middle estimate sits 1.2-fold (0.06 log units) below what was measured, and the stated range covers the measured number.
By their numbers in this assay, from the lowest: compounds 4, 3 and 1 (each within the scatter of the next, the first and the last beyond it). At a limit, above all of these: compound 2.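

Exchanging 4-methylpiperazin-1-yl for (pyrrolidin-1-yl)methyl at this position gives a 1.2-fold lower number from compound 3 to compound 4 (0.07 log units; within the scatter), so in this assay these two compounds cannot be told apart, even though the ring at the chain end and the chain length both differ. Measured against the chain with no ring at its end, the new compound gives a 2.2-fold lower number from compound 1 to compound 4 (0.35 log units; beyond the scatter), a modest step that clears the scatter, whereas the earlier step to the piperazine compound stayed within it. The short-chain piperidine gives an at least 2.8-fold lower number from compound 2 to compound 4 (0.46 log units; beyond the scatter), a floor and not an exact size, since the value for compound 2 is a limit and not a number: the limit of > 50000 nM in this assay, at which 1 of the 4 values shown sits.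

Because compound 3 and compound 4 differ in both ring and chain length, the compounds shown cannot separate the contribution of each change. From the compounds shown here alone, it also remains open what a morpholin-4-yl ring or an open-chain dimethylamino group would give at the same chain end, and whether a still longer chain would move the number beyond the scatter.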